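Two ortho-halogens in place of one on a shared core

This account rests on a few compounds, and the source may have more. Where it says the series, first, only, none or still open, it means among the compounds named here.

Compound 1 `Oc1c(C(Nc2ccccn2)c2ccccc2F)ccc2cccnc12` was tested in an assay for inhibition of protein disulfide-isomerase (Homo sapiens), with a stated time of 1 h (on this read-out lower numbers stand for stronger inhibition and higher numbers for weaker inhibition), where compound 1 gives 470 nM. Two other compounds, built on different cores, belong to the same set. Compound 3 `Oc1c(C(c2ccc(F)cc2)N2CCCCC2)ccc2c1OCCO2` gives 290 nM in this assay, and this number and that of compound 1 lie within the usual scatter of each other, so no order between them can be read. Compound 2 `CN(C)c1cccc(C(c2ccc(F)cc2)N2CCCCC2)c1O` reaches only a limit of the assay, > 30000 nM, in this assay (the limit of > 30000 nM in this assay, at which 1 of the 3 values shown sits). Among the numbers that are not limits, compound 1 therefore sits close to the only other one shown.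

Compound 4 `Oc1c(C(Nc2ccccn2)c2c(Cl)cccc2Cl)ccc2cccnc12` has not yet been measured. It differs from compound 1 in one place: 2,6-dichlorophenyl in place of 2-fluorophenyl on a saturated chain carbon bound to an aromatic carbon and a nitrogen on an aromatic ring. For the measured compounds named here, no pair of measured compounds differs in exactly this way, so the size of this step cannot be read from measured data. The step expected from this change, a 1.3-fold higher number from compound 1 to compound 4 (0.11 log units; within the scatter), is small and could run in either direction, most likely not far beyond the scatter. Compound 4 is estimated at 600 nM in this assay, with a range from 150 nM to 2500 nM.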

Compound 4, half-maximal inhibitory concentration: 1890 nM
For compound 4 the middle estimate is 3.2-fold (0.50 log units) below the measured one; low and high end bracket the measured number.
By their numbers in this assay, from the lowest: compounds 3 and 1 (each within the scatter of the next); then compound 4. At a limit, above all of these: compound 2.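

In this assay, for the compounds shown here, putting 2,6-dichlorophenyl in place of 2-fluorophenyl on a saturated chain carbon bound to an aromatic carbon and a nitrogen on an aromatic ring gives the first step that can be read in this set: a 4.0-fold higher number from compound 1 to compound 4 (0.60 log units; beyond the scatter). This position on the shared core therefore responds to a change in the halogens alone, since the six-membered aromatic ring of carbon stays and the counts of hydrogen-bond donors and acceptors stay the same, and the step runs towards weaker inhibition. The earlier compounds, built on different cores, could show nothing about this position, and no measurement shown here gives a cause for the step.

The change alters the kind of halogen and the number of halogens in one move, so the compounds shown cannot tell which of the two carries the step, and 2-chlorophenyl or 2,6-difluorophenyl at this place would separate them. As far as these compounds go, whether the same exchange would give a step of similar size on the cores of the other compounds also remains open.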